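This account rests on a few compounds, and the source may have more. Where it says the series, first, only, none or still open, it means among the compounds named here.

Measured so far:
- compound 1 `CC(C)=CCC/C(C)=C/CC/C(C)=C/CSC[C@H](NC(=O)OC(C)(C)C)C(=O)C=[N+]=[N-]`: in a functional assay on NALM-6 cells (Homo sapiens) (a higher number here means a weaker inhibitor, a lower number a stronger inhibitor), compound 1 gives 49800 nM.
- compound 2 `CC(=O)N[C@@H](CSCC=C(C)C)C(=O)C=[N+]=[N-]`: in this assay compound 2 gives > 100000 nM, which is a limit of the assay and not a number.

Compound 1 thus holds the only number shown; the other value sits at the limit of > 100000 nM in this assay, at which 1 of the 2 values shown sits. Compound 3 `CC(C)=CCC/C(C)=C/CC/C(C)=C/CSC[C@H](NC(=O)OC(C)(C)C)C(=O)CCl` differs from compound 1 by a group of 2 heavy atoms (1 carbon, 1 chlorine; no ring) in place of a group of 3 heavy atoms (1 carbon, 2 nitrogen; no ring), on a carbonyl carbon. Going by the values given here, no measured step of this kind exists in the set, so in this assay only a modest step toward a lower number is expected, a 2.0-fold lower number from compound 1 to compound 3 (0.30 log units; within the scatter). Compound 3 is estimated at 25000 nM, with a range from 5000 nM to 100000 nM.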

Compound 3, half-maximal inhibitory concentration: 10700 nM
Beside the measured number, compound 3's estimate is 2.3-fold (0.37 log units) above it; measured number inside the range.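

In this assay, going by these compounds alone, the carbonyl carbon of the shared core gives the first single-place comparison: chloromethyl in place of the group of 3 heavy atoms (1 carbon, 2 nitrogen) gives a 4.7-fold lower number from compound 1 to compound 3 (0.67 log units; beyond the scatter) in favour of chloromethyl. The position therefore tolerates this exchange and responds to it. No measurement shown accounts for the step.

Still open, on these data alone, is how bromomethyl or hydroxymethyl would read on the same carbonyl carbon. Also open, as far as these compounds go, is whether chloromethyl gives a comparable step on the shorter chain of compound 2.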